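Swapping chlorine for fluorine on a chalcone-like pyrazole series

This account rests on a few compounds, and the source may have more. Where it says the series, first, only, none or still open, it means among the compounds named here.

Measured compounds and their values in a functional assay on SK-MEL-2 cells (Homo sapiens) for cytotoxicity, read by sulforhodamine B assay, with a stated time of 48 h, tested at 100 uM; a lower number here means a stronger effect, a higher number a weaker effect of the compound at the concentration tested:
- compound 1, `COc1cc(-c2cc(/C=C/C(=O)c3ccc(Cl)c(Cl)c3)[nH]n2)cc(OC)c1OC`: -60%
- compound 2, `COc1ccc(-c2cc(/C=C/C(=O)c3ccc(N)cc3)[nH]n2)cc1OC`: -86%
- compound 3, `COc1ccc(-c2cc(/C=C/C(=O)c3cc(OC)c(OC)c(OC)c3)[nH]n2)cc1OC`: -92%

Among these three, compound 1 stands highest in this assay, which means it shows the weakest effect at the concentration tested. Its gap to compound 2 and its gap to compound 3 are both larger than the scatter that repeated measurements of this kind usually show, so the ranking of compound 1 below the other two is a real difference and not noise.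

Compound 4, `COc1cc(-c2cc(/C=C/C(=O)c3ccc(F)c(F)c3)[nH]n2)cc(OC)c1OC`, has not yet been measured. It differs from compound 1 in one place only: 3,4-difluorophenyl in place of 3,4-dichlorophenyl on a carbonyl carbon. Both groups are the same size and carry two halogens on the same ring; only the kind of halogen changes. Among the measured compounds shown here, no pair already measured shows such a swap, so there is no direct precedent to lean on.

Going from compound 1 to compound 4, the expected step in this assay is small, with the number expected to stay roughly where compound 1 sits or drift slightly higher, a move not clearly beyond the scatter: a number 10 percentage points higher from compound 1 to compound 4 (within the scatter). Compound 4 is therefore estimated at -50%, within a range from -78% to -20%.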

Compound 4, a percentage reported as activity, at one concentration (the size of the read-out at that concentration, not a potency): -64%
Compound 4: middle estimate off by 14 percentage points, on the high side; low and high end bracket the measured number.
By their numbers in this assay, from the lowest: compounds 3 and 2 (each within the scatter of the next); then compounds 4 and 1 (each within the scatter of the next).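

In this assay, among the compounds shown here, the swap to 3,4-difluorophenyl in place of 3,4-dichlorophenyl on a carbonyl carbon gives a number 4 percentage points lower from compound 1 to compound 4 (within the scatter) and is the first one-place comparison in this set. At this position, then, changing the kind of halogen on the ring while keeping both halogens produces no difference that this read-out, taken at a single concentration, can separate from the scatter. Nothing measured here offers a reason for this result.

Compounds 2 and 3 differ from compound 1 in more than one place, so their effects cannot be traced to the ring on the carbonyl carbon alone. As far as these compounds go, what a phenyl ring carrying a single chlorine, a trifluoromethyl group or a nitrile would give in this place remains open.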